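Chloro for Methyl Across Two Related Cores

This account rests on a few compounds, and the source may have more. Where it says the series, first, only, none or still open, it means among the compounds named here.

Compound 1 `Cc1ccc(NC(=S)NC(=O)c2ccc(OCc3ccc(Cl)c(Cl)c3)cc2)cc1-c1nc2ccccc2[nH]1`: 6270 nM
Compound 2 `O=C(NC(=S)Nc1ccc(Cl)c(-c2nc3ccccc3[nH]2)c1)c1ccc(OCc2ccc(Cl)c(Cl)c2)cc1`: 4930 nM
Compound 3 `Cc1ccc(NC(=O)NC(=O)c2ccc(OCc3ccccc3F)cc2)cc1-c1nc2ccccc2[nH]1`: 760 nM

All three numbers come from a functional assay on HT-29 cells (Homo sapiens) for inhibition, read by MTT assay, with a stated time of 48 h; on this read-out lower numbers stand for stronger inhibition and higher numbers for weaker inhibition. Compound 1 and compound 2 differ in one place, (chloro in place of methyl on an aromatic carbon), and the measured step is a 1.3-fold lower number from compound 1 to compound 2 (0.10 log units; within the scatter). Compound 3 carries the lowest number of the three; how its core differs from the core of compound 1 is not broken down here. Compound 4 `O=C(NC(=O)c1ccc(OCc2ccccc2F)cc1)Nc1ccc(Cl)c(-c2nc3ccccc3[nH]2)c1` has not yet been measured in this assay. It differs from compound 3 by chloro in place of methyl on an aromatic carbon, the same change at the same place as that between compound 1 and compound 2. The expected step is a 1.3-fold lower number from compound 3 to compound 4 (0.10 log units; within the scatter). This rests on a 1.3-fold lower number from compound 1 to compound 2 (0.10 log units; within the scatter), which lies within the scatter, and on compound 3 at 760 nM. Compound 4 is therefore estimated at 600 nM in this assay, with a likely range from 250 nM to 1500 nM.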

Compound 4, half-maximal inhibitory concentration: 590 nM
Compound 4: the middle estimate sits 1.0-fold (0.01 log units) above what was measured; low and high end bracket the measured number.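

In this assay, chloro in place of methyl on an aromatic carbon gives a 1.3-fold lower number from compound 3 to compound 4 (0.11 log units; within the scatter) and this step agrees with the one seen earlier on the other core: the same change on two cores in this assay, a 1.3-fold lower number (0.10 log units; within the scatter) from compound 1 to compound 2 and a 1.3-fold lower number (0.11 log units; within the scatter) from compound 3 to compound 4, 1.0-fold (0.01 log units) apart, within the scatter of two such steps. The change therefore carries from the core of compound 1 to the core of compound 3 with no measurable shift in its size. It does not show that the change moves the number on either core, since both steps lie within the scatter, and two cores say nothing about further ones. The compounds shown leave open whether an amine, a methoxy group or a carboxylic acid at the same place would give a step beyond the scatter.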